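Branched alkyl on the double-bonded nitrogen: compound 1 to compound 4

This account rests on a few compounds, and the source may have more. Where it says the series, first, only, none or still open, it means among the compounds named here.

The series shares one core. Compound 1 `CCCC/N=c1\c(O)c(O)\c1=N/Cc1ccc(C#N)cc1` carries a butyl group on one double-bonded nitrogen and a nitrile-bearing benzyl on the other. In a functional assay for inhibition, with Rattus norvegicus as the target (a lower number here means a stronger inhibitor, a higher number a weaker inhibitor), compound 1 gives > 30000 nM, which is a limit of the assay and not a number (the limit of > 30000 nM in this assay, at which 1 of the 3 values shown sits). Compound 2 `Cc1cc(Cl)cc(Cl)c1C/N=c1\c(O)c(O)\c1=N/C(C)(C)C` gives 220 nM in this assay. Compound 3 `Cc1cc(C#N)cc(Cl)c1C/N=c1\c(O)c(O)\c1=N/C(C)C(C)(C)C` gives 1900 nM in this assay. Among the measured compounds shown here, both carry a branched alkyl on the double-bonded nitrogen and both return a number, but their benzyl groups also differ from that of compound 1, so no single-change step between measured compounds is available.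

Compound 4 `CCC(C)(C)/N=c1\c(O)c(O)\c1=N/Cc1ccc(C#N)cc1` differs from compound 1 in one place: 1,1-dimethylpropyl in place of butyl on a double-bonded nitrogen. For the measured compounds named here, no measured pair isolates this change. The expected step in this assay is an at least 2.5-fold lower number from compound 1 to compound 4 (0.39 log units; beyond the scatter), a gain beyond the scatter but a modest one, since the starting point is only a limit. Compound 4 is expected at 12000 nM, with a range from 2500 nM to 60000 nM, and a real chance that it again returns only a limit.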

Compound 4, half-maximal inhibitory concentration: 1100 nM
Estimate against measurement, compound 4: 11-fold (1.04 log units) above, outside the stated range (below it).
By their numbers in this assay, from the lowest: compound 2; then compounds 4 and 3 (each within the scatter of the next). At a limit, above all of these: compound 1.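

In this assay, among the compounds shown here, 1,1-dimethylpropyl in place of butyl on a double-bonded nitrogen gives an at least 27-fold lower number from compound 1 to compound 4 (1.43 log units; beyond the scatter), the first single-change step and a large one. With the nitrile-bearing benzyl held fixed, compound 4 returns a number from this change alone; compounds 2 and 3 could not show that, as their benzyl groups also differ from that of compound 1. Compound 1 is at a limit of the assay, so the step is a bound and not an exact size: the limit of > 30000 nM in this assay, at which 1 of the 4 values shown sits.

With only these two alkyl groups compared on this benzyl, the data do not separate the branching from the added carbon; a straight pentyl chain on the same benzyl would do so. As far as these compounds go, whether the step holds on the chlorinated benzyl groups of compounds 2 and 3, or with a cyclohexyl group at this position, also remains open.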